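Swapping the aryl group on the ring nitrogen of a shared core

The source may hold more compounds than are shown below. What is called first, only, known or untested is meant among the compounds shown, and "the series" means these compounds.

In a functional assay on MCF7 cells (Homo sapiens) for inhibition, read by MTT assay, with a stated time of 72 h (a lower number here means a stronger inhibitor, a higher number a weaker inhibitor), compound 2 `COc1ccccc1Nc1nc(SCc2cn(CC(=O)NC(=O)Nc3ccccn3)nn2)nc(-c2ccc(C(C)C)cc2)c1C#N` gives 19300 nM. Compound 3 `COc1ccccc1Nc1nc(SCc2cn(CC(=O)NC(=O)Nc3ccccn3)nn2)nc(-c2ccc(C)cc2)c1C#N` gives 19700 nM in this assay. Compound 1 `Cc1ccc(Nc2nc(SCc3cn(CC(=O)NC(=O)Nc4ccccn4)nn3)nc(-c3ccc(C(C)C)cc3)c2C#N)cc1` reaches only a limit of this assay, > 64000 nM. The change 4-methylphenyl in place of 2-methoxyphenyl on a nitrogen on an aromatic ring thus gives an at least 3.3-fold higher number from compound 2 to compound 1 (0.52 log units; beyond the scatter), with the upper value resting on (the limit of > 64000 nM in this assay, at which 1 of the 3 values shown sits). The core change between compound 2 and compound 3, (methyl in place of isopropyl on an aromatic carbon), gives a 1.0-fold higher number from compound 2 to compound 3 (0.01 log units; within the scatter). Compound 4 `Cc1ccc(Nc2nc(SCc3cn(CC(=O)NC(=O)Nc4ccccn4)nn3)nc(-c3ccc(C)cc3)c2C#N)cc1` differs from compound 3 by 4-methylphenyl in place of 2-methoxyphenyl on a nitrogen on an aromatic ring, the same change as from compound 2 to compound 1, at the same place. Since compound 3 matches compound 2 in this assay and the same change gave an at least 3.3-fold higher number from compound 2 to compound 1 (0.52 log units; beyond the scatter), the expected step is a 3.6-fold higher number from compound 3 to compound 4 (0.55 log units; beyond the scatter). Compound 4 is therefore estimated at 70000 nM in this assay, most likely again reported only as a limit.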

Compound 4, half-maximal inhibitory concentration: 39600 nM
For compound 4 the middle estimate is 1.8-fold (0.25 log units) above the measured one, and the stated range covers the measured number.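

In this assay, 4-methylphenyl in place of 2-methoxyphenyl on the nitrogen gives a 2.0-fold higher number from compound 3 to compound 4 (0.30 log units; within the scatter). Methyl in place of isopropyl on the aromatic carbon, read with 4-methylphenyl on the nitrogen, gives an at least 1.6-fold lower number from compound 1 to compound 4 (0.20 log units; that floor lies within the scatter), and this step rests on compound 1, whose value is a limit of the assay. The nitrogen change is therefore neither shown to carry over from one core to the other with the same size nor shown to differ between them: the same change on two cores in this assay, an at least 3.3-fold higher number (0.52 log units; beyond the scatter) from compound 2 to compound 1 and a 2.0-fold higher number (0.30 log units; within the scatter) from compound 3 to compound 4; the limit leaves it open whether they differ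

A chlorophenyl or a pyridyl group on that nitrogen remains open, so the two aryl groups shown give no wider trend. On these data alone, whether the nitrogen change holds with a chlorine or a longer alkyl chain in place of methyl or isopropyl also remains open.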